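A few compounds are considered here, and "the series" means these few. Any claim that something is new, unique, unknown or untested is made for them only; others in the source may bear on it.

Working notes on the series of aryl ureas on a shared core, all assessed in a functional assay on NCI-H23 cells (Homo sapiens) for inhibition, read by sulforhodamine B assay, with a stated time of 48 h; a higher number here means that more compound is tolerated, a lower number that less compound is tolerated.

Compound 1 `O=C(Nc1cccc(-n2cc(-c3ccncc3)c(-c3ccc(Cl)c(O)c3)n2)c1)Nc1cccc(C(F)(F)F)c1` gives in this assay a value of > 32500 nM, which is a limit of the assay and not a number. Compound 2 `COc1cc(-c2nn(-c3cccc(NC(=O)Nc4cccc(C(F)(F)F)c4)c3)cc2-c2ccncc2)ccc1Cl` gives in this assay a value of > 50000 nM, again a limit rather than a number. Compound 3 `COc1cc(-c2nn(-c3cccc(NC(=O)Nc4ccc(Cl)c(C(F)(F)F)c4)c3)cc2-c2ccncc2)ccc1Cl` gives in this assay a value of > 32500 nM, also a limit.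

Compound 2 and compound 1 differ by hydrogen in place of methyl on an oxygen on an aromatic ring. The step that the two limits leave unreadable from compound 2 to compound 1 stays unreadable because the two values sit at the limit of > 50000 nM in this assay, at which 1 of the 3 values shown sits, and at the limit of > 32500 nM in this assay, at which 2 of the 3 values shown sit. The cores of compound 2 and compound 3 differ by chloro in place of hydrogen on an aromatic carbon. The step that the two limits leave unreadable from compound 2 to compound 3 is likewise unreadable because both values sit at the limit of > 50000 nM in this assay, at which 1 of the 3 values shown sits, and at the limit of > 32500 nM in this assay, at which 2 of the 3 values shown sit.

Compound 4 `O=C(Nc1cccc(-n2cc(-c3ccncc3)c(-c3ccc(Cl)c(O)c3)n2)c1)Nc1ccc(Cl)c(C(F)(F)F)c1` differs from compound 3 by hydrogen in place of methyl on an oxygen on an aromatic ring, the same change as that from compound 2 to compound 1, at the same place on the shared core. The step that the limit leaves unreadable from compound 3 to compound 4 is expected to be small, since compound 3 sits at > 32500 nM and the parallel step from compound 2 to compound 1 left both partners at a limit. Compound 4 is therefore expected to give in this assay roughly 40000 nM, most likely reported again as a limit, with a plausible band from 20000 nM to 70000 nM.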

Compound 4, concentration lethal to 50% of the cells: 26100 nM
Beside the measured number, compound 4's estimate is 1.5-fold (0.19 log units) above it, within the range that was stated.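

In this assay compound 4 gives 26100 nM, the only value among the compounds shown that is not a limit, and the methoxy to hydroxy change on the core that carries the added chloro gives an at least 1.2-fold lower number from compound 3 to compound 4 (0.09 log units; that floor lies within the scatter). Adding the chloro to the hydroxy core gives an at least 1.2-fold lower number from compound 1 to compound 4 (0.09 log units; that floor lies within the scatter), so neither step, read at its floor, can be separated from the scatter of this assay. The matching steps on the other core, methoxy to hydroxy and the addition of chloro starting from compound 2, cannot be read, so the notes show one direction compatible with the data on a single core but do not show that the methoxy to hydroxy change carries from one core to another with the same size or even the same direction.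

Still open, from the compounds shown here alone, is whether an ethoxy group, an amine or a carboxylic acid in place of the hydroxy on the 4-chloro-3-hydroxyphenyl group would give a value in this assay that is clear of the scatter relative to compound 4. Also open, going by these compounds, is whether the chloro step has any readable size on a core where both partners give numbers rather than limits.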